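This account rests on a few compounds, and the source may have more. Where it says the series, first, only, none or still open, it means among the compounds named here.

Compound 1 `CC(Cc1ccc(Cl)cc1)(Oc1ccc(Oc2ccccc2)cc1)C(=O)O` and compound 2 `CCc1ccc(CC(C)(Oc2ccc(Oc3ccccc3)cc2)C(=O)O)cc1` share one core. In a functional assay on the whole organism for inhibition, with Rattus norvegicus as the target (on this read-out higher numbers stand for an effect only at larger amounts of compound and lower numbers for an effect already at smaller amounts), compound 1 reaches only a limit of the assay, < 1 mg/kg, namely (the limit of < 1 mg/kg in this assay, at which 1 of the 3 values shown sits). In this assay compound 2 gives 1 mg/kg. As far as these compounds go, the change between them is ethyl in place of chloro on an aromatic carbon, and the step is a number no lower from compound 1 to compound 2 (the limit leaves the size open); as compound 1 sits at a limit, the size of that step stays open. Compound 3 `CC(C)c1ccc(OC(C)(Cc2ccc(Cl)cc2)C(=O)NS(=O)(=O)C(F)(F)F)cc1` carries a different core; the difference between the two cores is not broken down here. In this assay compound 3 gives 5 mg/kg, the higher of the two plain numbers. Compound 4 `CCc1ccc(CC(C)(Oc2ccc(C(C)C)cc2)C(=O)NS(=O)(=O)C(F)(F)F)cc1` differs from compound 3 by ethyl in place of chloro on an aromatic carbon, the same change as from compound 1 to compound 2. For compound 4 a step of a 1.4-fold higher number from compound 3 to compound 4 (0.15 log units; within the scatter) is expected because the earlier step of a number no lower from compound 1 to compound 2 (the limit leaves the size open) ran no lower. Compound 4 is therefore expected at 7 mg/kg, between 3 mg/kg and 20 mg/kg.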

Compound 4, dose for half-maximal effect: > 10 mg/kg
Compound 4: a limit, no number; the forecaster's own chance of this, stated with the estimate: 10%; middle value at least 1.4-fold (0.15 log units) from the limit.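

In this assay, compound 4 reaches only a limit of the assay, > 10 mg/kg, and not a number. On the core of compound 3, ethyl in place of chloro gives an at least 2.0-fold higher number from compound 3 to compound 4 (0.30 log units; that floor lies within the scatter). Neither core shows a lower number with ethyl, but this does not show that the change carries over with the same size, and the two steps cannot be set against each other: the same change on two cores in this assay, a number no lower (the limit leaves the size open) from compound 1 to compound 2 and an at least 2.0-fold higher number (0.30 log units; that floor lies within the scatter) from compound 3 to compound 4; the limit leaves it open whether they differ

As far as these compounds go, what a methyl group or a methoxy group in place of chloro would give on either core stays open. From the compounds shown here alone, the true size of each step also stays open, as each pair has a limit at one end.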